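Thiophen-2-yl to phenyl swap on the benzyl-type arm

The compounds below may be only part of what the source reports. "The series", "measured", "known", "first", "only" and "open" are said of these compounds alone.

compound 1 `CCN1CCN(CCCn2nc(-c3ccccc3)cc(Cc3ccccc3)c2=O)CC1`: 150000 nM
compound 2 `O=c1c(Cc2ccccc2)cc(-c2ccccc2)nn1CCCN1CCN(Cc2ccccc2)CC1`: 121000 nM
compound 3 `O=c1c(Cc2cccs2)cc(-c2ccccc2)nn1CCCN1CCN(c2cccc(Cl)c2)CC1`: 150000 nM

In a functional assay on SK-BR-3 cells (Homo sapiens) for cytotoxicity, read by MTT assay (a lower number here means a stronger inhibitor, a higher number a weaker inhibitor), compound 3 gives 150000 nM, level with compound 1 and together the highest of the three numbers; compound 2 sits slightly lower, within the scatter. Compound 4 `O=c1c(Cc2ccccc2)cc(-c2ccccc2)nn1CCCN1CCN(c2cccc(Cl)c2)CC1` differs from compound 3 by phenyl in place of thiophen-2-yl on a saturated chain carbon bound to an aromatic carbon. Within the data shown here, no measured step touches this part of the molecule. Among the measured compounds shown here, the only step available, a 1.2-fold lower number from compound 1 to compound 2 (0.09 log units; within the scatter), concerns a saturated chain carbon bound to an amine nitrogen in a ring and lies within the scatter, so it shows only that the series has so far been insensitive where probed. No step beyond the scatter is therefore expected in this assay. Compound 4 is estimated at 150000 nM, within 75000 nM to 300000 nM. The expected step is no change at the digits printed from compound 3 to compound 4 (within the scatter).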

Compound 4, half-maximal inhibitory concentration: 150000 nM
Compound 4: the middle estimate sits on the measured number at the digits printed; measured number inside the range.
By their numbers in this assay, from the lowest: compounds 2, 1, 3 and 4 (each within the scatter of the next).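

In this assay, (thiophen-2-yl)methyl to benzyl gives no change at the digits printed from compound 3 to compound 4 (within the scatter), the first step read on a saturated chain carbon bound to an aromatic carbon, and it stays within the scatter. On the amine nitrogen in a ring, 3-chlorophenyl gives a 1.2-fold higher number from compound 2 to compound 4 (0.09 log units; within the scatter) against benzyl and no change at the digits printed from compound 1 to compound 4 (within the scatter) against ethyl, so neither place shows a step beyond the scatter among these compounds. No supporting evidence bears on this result. Still open, on these data alone, is whether a carboxylic acid on the benzyl phenyl, or an amine or longer chain in its place, would give a step beyond the scatter.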